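The source may report more compounds than this note shows. Statements on the series, on what has been measured and on what is new or still open speak of the compounds shown alone.

Working notes on the series. Going by the values given here, the two measured members are compound 1 `ClCc1ccc(Cn2cnc3c(Cl)ncnc32)cc1` and compound 2 `ClCc1ccccc1Cn1cnc2c(Cl)nc(Cl)nc21`. In a functional assay on OVCAR-4 cells (Homo sapiens) for cytotoxicity, read by sulforhodamine B assay, with a stated time of 48 h (a lower number here means a stronger inhibitor of growth, a higher number a weaker inhibitor of growth), compound 2 gives 1770 nM. In this assay compound 1 gives 2450 nM. Compound 2 thus has the lower of the two numbers, but the gap to compound 1 lies within the scatter, so the two compounds are read as equivalent on the data so far.

The next member, compound 3 `ClCc1ccccc1Cn1cnc2c(Cl)ncnc21`, has not yet been measured in this assay. Relative to compound 2 the change is hydrogen in place of chloro on an aromatic carbon, with the rest of the molecule kept. Among the compounds with values here, no measured pair shows the effect of this change alone. Compound 1, which carries the same core as compound 3 but a different benzyl substitution, sits within the scatter of compound 2, which gives no sign that the added chloro on compound 2 counts for much here.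

For compound 3 the step from compound 2 is expected to be small, a 1.5-fold higher number from compound 2 to compound 3 (0.17 log units; within the scatter), not beyond the scatter in either direction. Compound 3 is accordingly estimated at 2600 nM, with a range from 1000 nM to 6800 nM.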

Compound 3, concentration for 50% growth inhibition: 3380 nM
The estimate for compound 3 lay 1.3-fold (0.11 log units) below the measured number, and the stated range covers the measured number.
By their numbers in this assay, from the lowest: compounds 2, 1 and 3 (each within the scatter of the next).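

The pair compound 2 and compound 3 now isolates the chloro on the aromatic carbon between two ring nitrogen atoms: in this assay, replacing it with hydrogen gives a 1.9-fold higher number from compound 2 to compound 3 (0.28 log units; within the scatter). On this single pair, with the other chloro on that ring and the benzyl substitution held constant, the two compounds are read as equivalent, so removing this chloro has no effect on growth inhibition that can be told from the scatter. No measurement shown bears on why this step is as it is, and no explanation can be offered from the data at hand.

The compounds shown carry only chloro or hydrogen at this position, so the outcome with an amine or a methoxy group there remains open, as does whether the same replacement reads alike with the benzyl substitution of compound 1. The chloromethyl group is common to all three compounds, so the series also gives no reading of what a hydroxymethyl group in its place would do.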